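The source may hold more compounds than are shown below. What is called first, only, known or untested is meant among the compounds shown, and "the series" means these compounds.

Compound 3, `O=C(/C=C/c1ccc(O)cc1)c1c(O)cccc1OCC1CCCC1`, gives 3410 nM in a functional assay on MDA-MB-231 cells (Homo sapiens) for antiproliferative activity, read by sulforhodamine B assay (on this read-out higher numbers stand for weaker inhibition of growth and lower numbers for stronger inhibition of growth), the highest of the two numbers available, though its neighbour compound 2, `O=C(/C=C/c1ccc(O)cc1)c1c(O)cccc1OCCC1CCCC1`, with 3340 nM sits so close that a 1.0-fold higher number from compound 2 to compound 3 (0.01 log units; within the scatter) shows the two are not separated. Compound 1, `CCCCCCOc1cccc(O)c1C(=O)/C=C/c1ccc(O)cc1`, returns only a limit, > 30000 nM (the limit of > 30000 nM in this assay, at which 1 of the 3 values shown sits). Both compounds with a five-membered ring on the chain lie far from that limit: an at least 8.9-fold lower number from compound 1 to compound 2 (0.95 log units; beyond the scatter) and an at least 8.7-fold lower number from compound 1 to compound 3 (0.94 log units; beyond the scatter).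

Compound 4, `CC(C)CCOc1cccc(O)c1C(=O)/C=C/c1ccc(O)cc1`, differs from compound 3 in one place: isobutyl in place of cyclopentyl on a saturated chain carbon bound to an oxygen on an aromatic ring. The ring that set compound 2 and compound 3 apart from compound 1 is given up for a short branched chain, so the change runs back toward the acyclic side of the series. Two measured steps bear on it, both moving away from an acyclic chain to cyclopentyl and both lowering the number by at least the size shown in an at least 8.7-fold lower number from compound 1 to compound 3 (0.94 log units; beyond the scatter); the reverse direction is therefore expected to raise it. Since isobutyl is shorter than the pentyl and hexyl of compound 1, the full return to the limit is not assumed. Compound 4 is estimated at 12000 nM, with a range from 4000 nM to 35000 nM, which means an expected step of a 3.5-fold higher number from compound 3 to compound 4 (0.55 log units; beyond the scatter).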

Compound 4, concentration for 50% growth inhibition: 10300 nM
For compound 4 the middle estimate is 1.2-fold (0.07 log units) above the measured one; low and high end bracket the measured number.
By their numbers in this assay, from the lowest: compounds 2 and 3 (each within the scatter of the next); then compound 4. At a limit, above all of these: compound 1.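

Giving up the ring costs something at this position, a 3.0-fold higher number from compound 3 to compound 4 (0.48 log units; beyond the scatter), and the comparison with the compound that carries the ring one carbon further out reads the same, a 3.1-fold higher number from compound 2 to compound 4 (0.49 log units; beyond the scatter). An open chain alone, however, does not take the number to the limit in this assay: the isopentyl chain of compound 4 gives a measured value that lies clear of the hexyl chain of compound 1, with an at least 2.9-fold lower number from compound 1 to compound 4 (0.46 log units; beyond the scatter). Compound 1 remains a limit and not a number, so that last step is only a bound and the full distance between the two open chains stays unknown: the limit of > 30000 nM in this assay, at which 1 of the 4 values shown sits.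

The compounds shown leave open whether the length of the chain or its branch decides the value of compound 4, a question that a straight butyl or pentyl chain on the same oxygen would address, and whether a cyclohexyl ring would read like the cyclopentyl ones. They also say nothing about how an amine or a carboxylic acid at the end of the chain would behave in this read-out.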